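This account rests on a few compounds, and the source may have more. Where it says the series, first, only, none or still open, it means among the compounds named here.

Measured in a functional assay on HEK293 cells for agonist activity at Vasopressin V2 receptor (Homo sapiens), read by a luciferase reporter and cAMP accumulation; on this read-out lower numbers stand for an effect already at smaller amounts and higher numbers for an effect only at larger amounts of compound:

compound 1 `CCc1cc(C(=O)N2CCCCc3ccccc32)ccc1CNC(=O)Nc1c(F)cccc1F`, compound 1 gives 10 nM
compound 2 `Cc1cc(C(=O)N2CCCCc3ccccc32)cc(C)c1CNC(=O)Nc1c(F)cccc1F`, compound 2 gives 82 nM
compound 3 `COC(=O)CNC(=O)NCc1ccc(C(=O)N2CCCCc3ccccc32)cc1C`, compound 3 gives 37 nM

Compound 3 holds the second highest of the three numbers in this assay. Its nearest neighbour is compound 2, whose number lies higher by more than the scatter; the furthest is compound 1, whose number lies lower, also beyond the scatter. Compound 3 thus sits between the two, closer to compound 2.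

Compound 4 `Cc1cc(C(=O)N2CCCCc3ccccc32)ccc1CNC(=O)N1CCC[C@H]1C(=O)O` is not yet measured. It differs from compound 3 in one place: 2-carboxypyrrolidin-1-yl in place of ((methoxycarbonyl)methyl)amino on a carbonyl carbon. Among the compounds with values here, no measured pair shows this kind of change, so there is no step to lean on, and the shared core is carried over unchanged.

Without a comparable step, the expectation is a modest move in this assay, most likely towards a somewhat higher number, not far beyond the scatter. For compound 4 the estimated value is 60 nM, within 15 nM to 250 nM, which corresponds to an expected step of a 1.6-fold higher number from compound 3 to compound 4 (0.21 log units; within the scatter).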

Compound 4, half-maximal effective concentration: 680 nM
Estimate against measurement, compound 4: 11-fold (1.05 log units) below, outside the stated range (above it).
By their numbers in this assay, from the lowest: compound 1; then compound 3; then compound 2; then compound 4.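

In this assay, within the data shown here, 2-carboxypyrrolidin-1-yl in place of ((methoxycarbonyl)methyl)amino on a carbonyl carbon gives an 18-fold higher number from compound 3 to compound 4 (1.26 log units; beyond the scatter), the first one-place step. The group on this carbonyl carbon alone can therefore shift the number well beyond the scatter, and in this case the shift is towards a higher number. The change combines a five-membered ring, a free carboxylic acid in place of a methyl ester and a defined stereocentre, and nothing available bears on what lies behind the step.

The contributions of these features remain unseparated: an open-chain (carboxymethyl)amino group would keep the acid without the ring, while a 2-(methoxycarbonyl)pyrrolidin-1-yl group would keep the ring with the ester. Plain pyrrolidin-1-yl and the opposite stereoisomer of 2-carboxypyrrolidin-1-yl are also open.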